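This account rests on a few compounds, and the source may have more. Where it says the series, first, only, none or still open, it means among the compounds named here.

Measured so far in an assay on isolated protein for inhibition of ubiquitin carboxyl-terminal hydrolase 7 (Homo sapiens), read by fluorescence, with stated times of 30 min and 1 h; a lower number here means a stronger inhibitor, a higher number a weaker inhibitor:
compound 1 `Cc1cc(Cl)cc(-c2ccnc3cc(CN4C(=O)CCC4=O)sc23)c1O[C@H]1C[C@H](N)C1`, 3.4 nM;
compound 2 `Cc1cc(Cl)cc(-c2ccnc3cc(CN4C(=O)CCC4=O)sc23)c1CN1CCNC[C@@H]1C`, 6.6 nM;
compound 3 `Cc1cc(Cl)cc(-c2ccnc3cc(CN4C(=O)C5C(C4=O)C5(C)C)sc23)c1CC1CCCNC1`, 1.3 nM.

Compound 3 gives the lowest number of the three, and its gaps to compound 1 and to compound 2 both lie beyond the scatter, so on these numbers it is the strongest inhibitor of the set. Compound 4 `Cc1cc(Cl)cc(-c2ccnc3cc(CN4C(=O)C5C(C4=O)C5(C)C)sc23)c1O[C@@H]1CCNC[C@@H]1C` has not yet been measured. It differs from compound 3 at a single point: (3-methylpiperidin-4-yl)oxy in place of (piperidin-3-yl)methyl on an aromatic carbon. All three measured compounds differ from one another at this same position, so the earlier results speak to this kind of change. For the measured compounds named here, the only measured step that alters just this position is a 1.9-fold higher number from compound 1 to compound 2 (0.29 log units; within the scatter), which stayed within the scatter. Compound 1 and compound 3 also differ here, but they differ elsewhere as well, so their gap cannot be assigned to this position alone. Because a 1.9-fold higher number from compound 1 to compound 2 (0.29 log units; within the scatter) was within the scatter, the step of a 1.9-fold higher number from compound 3 to compound 4 (0.28 log units; within the scatter) is expected to be small, most likely a modest rise in the number. Compound 4 is therefore estimated at 2.5 nM, within a range of 1 nM to 7 nM.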

Compound 4, half-maximal inhibitory concentration: 0.18 nM
Compound 4: middle estimate off by 14-fold (1.14 log units), on the high side; the measured number lies below the stated range.
By their numbers in this assay, from the lowest: compound 4; then compound 3; then compounds 1 and 2 (each within the scatter of the next).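

In this assay, for the compounds shown here, placing (3-methylpiperidin-4-yl)oxy where (piperidin-3-yl)methyl stood gives a 7.2-fold lower number from compound 3 to compound 4 (0.86 log units; beyond the scatter) and lies beyond the scatter, while the only earlier change confined to this position, a 1.9-fold higher number from compound 1 to compound 2 (0.29 log units; within the scatter), stayed within it. This aromatic carbon, ortho to a methyl group and para to a chloro group, is therefore not indifferent to what it carries: a change here alone can shift the number well beyond the scatter. Nothing available explains why this change lowers the number.

The step alters the connecting atom, the ring attachment and the ring methyl all at once, so the compounds shown leave open how much each contributes. A plain (piperidin-4-yl)oxy group, without the methyl, or the same group with its two stereocentres reversed, would help separate these contributions.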